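The source may report more compounds than this note shows. Statements on the series, on what has been measured and on what is new or still open speak of the compounds shown alone.

In an ADME assay (liver) for metabolic stability, with Liver microsome (Homo sapiens) as the target, read by LC-MS, using microsomes and NADPH, with a stated time of 5 min, at 37 degrees C (a lower number here means slower removal, a higher number faster removal of the compound), three compounds have been measured:

- compound 1 `CCn1c([C@@H](C)NS(=O)(=O)c2ccc(Cl)cc2)nc2cc(C#N)ccc21` gives 71 mL.min-1.g-1
- compound 2 `CCn1c(C(C)NS(=O)(=O)c2ccc(Cl)cc2)nc2ncccc21` gives 15 mL.min-1.g-1
- compound 3 `CCn1c([C@@H](C)NS(=O)(=O)C2CC2)nc2ccc(C(F)(F)F)cc21` gives < 3 mL.min-1.g-1 (a limit, not a number)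

Compound 3 gives < 3 mL.min-1.g-1 as a limit of the assay, so its true value is not known. Among the compounds with values here, it is the only one of the three compounds that sits at such a limit (the limit of < 3 mL.min-1.g-1 in this assay, at which 1 of the 3 values shown sits).

Compound 4 `CCn1c([C@@H](C)NS(=O)(=O)c2cccc(Cl)c2)nc2ccc(C(F)(F)F)cc21` keeps the core of compound 3 and carries 3-chlorophenyl in place of cyclopropyl on a sulfonyl sulfur. Within the data shown here, no pair of measured compounds differs in one place, so this change has no direct precedent. Among the measured compounds shown here, the only guide is that compound 1 gives 71 mL.min-1.g-1 and compound 2 gives 15 mL.min-1.g-1, both with a chlorophenyl on the sulfonyl sulfur, though on other cores and not as the same isomer as in compound 4.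

On that basis a clear rise beyond the scatter is expected in this assay for compound 4, with faster removal than compound 3. The estimated change is an at least 11-fold higher number from compound 3 to compound 4 (1.06 log units; beyond the scatter) (an expectation, not a measurement). For compound 4 the estimated value is 35 mL.min-1.g-1 (12 mL.min-1.g-1 to 100 mL.min-1.g-1).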

Compound 4, intrinsic clearance in microsomes: > 100 mL.min-1.g-1
Compound 4: a limit, no number; the forecaster's own chance of this, stated with the estimate: 5%; at least 2.8-fold (0.45 log units) between middle value and limit.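

In this assay, with the core of compound 3 kept, putting 3-chlorophenyl in place of cyclopropyl on a sulfonyl sulfur, whose other neighbour is the sulfonamide nitrogen, gives an at least 33-fold higher number from compound 3 to compound 4 (1.52 log units; beyond the scatter). Within the data shown here, this is the first comparison that changes this one place alone, and it shows that the group on the sulfonyl sulfur can by itself carry the read-out from one limit of the assay to the other, something compound 1 and compound 2, on other cores, could not show. Compound 4 gives a limit and not a number, as compound 3 does, so the true size of the step stays unknown: the limit of > 100 mL.min-1.g-1 in this assay, at which 1 of the 4 values shown sits.

The compounds shown do not separate the contribution of the aromatic ring from that of the chlorine, and a plain phenyl on the same sulfonyl sulfur would begin to settle that. Nor do they show where between the two limits a small open chain such as methyl or ethyl, or a phenyl bearing an amine, would fall on this core.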